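The compounds below may be only part of what the source reports. "The series", "measured", "known", "first", "only" and "open" are said of these compounds alone.

Working notes on the series. Two members have been measured in a functional assay on ECa-109 cells (Homo sapiens) for cytotoxicity, read by MTT assay, with a stated time of 48 h; on this read-out higher numbers stand for weaker inhibition and lower numbers for stronger inhibition. Compound 1 `O=C1C(O)=C(C(c2ccccc2)c2c(-c3ccccc3)[nH]c3ccccc23)C(=O)c2ccccc21` carries a plain phenyl on the saturated chain carbon and a second phenyl on the indole nitrogen-bearing ring; in this assay compound 1 gives 5180 nM. Compound 2 `COc1ccc(C(C2=C(O)C(=O)c3ccccc3C2=O)c2c[nH]c3ccccc23)cc1Br` carries a 3-bromo-4-methoxyphenyl on the saturated chain carbon and an unsubstituted indole; in this assay compound 2 gives 11800 nM. Compound 2 thus stands highest of the two numbers, and its gap to compound 1 lies beyond the scatter, so on these two values compound 2 is the weaker inhibitor. Within the data shown here, no step between compounds that differ in a single place is available, so the change cannot be read against a measured precedent.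

Compound 3 `COc1cccc(C(C2=C(O)C(=O)c3ccccc3C2=O)c2c[nH]c3ccccc23)c1` is the next member, not yet measured. Its change from compound 2 is 3-methoxyphenyl in place of 3-bromo-4-methoxyphenyl on a saturated chain carbon bound to an aromatic carbon and a double-bonded ring carbon. Among the measured compounds shown here, with no single-place precedent, a small step is expected in this assay, if any, towards a lower number, at the edge of the scatter: the expected step is a 1.5-fold lower number from compound 2 to compound 3 (0.17 log units; within the scatter). Compound 3 is estimated at 8000 nM, with a range from 3000 nM to 20000 nM.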

Compound 3, half-maximal inhibitory concentration: 40000 nM
Compound 3: middle estimate off by 5.0-fold (0.70 log units), on the low side; measured number above the stated range.
By their numbers in this assay, from the lowest: compound 1; then compound 2; then compound 3.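

In this assay, among these compounds, the aryl group on a saturated chain carbon bound to an aromatic carbon and a double-bonded ring carbon proves not to be a silent place: 3-methoxyphenyl in place of 3-bromo-4-methoxyphenyl gives a 3.4-fold higher number from compound 2 to compound 3 (0.53 log units; beyond the scatter) as the first single-place step. The step runs towards weaker inhibition and lies beyond the scatter, so with the rest of the core held constant, 3-bromo-4-methoxyphenyl is the better of these two groups at this place. Nothing available bears on why the number rises at this change.

The step takes away the bromine and, as the two group names show, also alters the numbered place of the methoxy, so the compounds shown leave open which of the two differences accounts for the higher number. They also leave open how this place would respond to a different kind of substituent on the phenyl, such as an amine or a carboxylic acid, since only these two aryl groups can be compared here in a single-place step.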